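Swapping chloro for phenyl on a sulfonamide pair

A few compounds are considered here, and "the series" means these few. Any claim that something is new, unique, unknown or untested is made for them only; others in the source may bear on it.

In a functional assay on P388 cells (Mus musculus) for antiproliferative activity, read by colorimetric assay and MTT assay (a higher number here means a weaker inhibitor, a lower number a stronger inhibitor), compound 1, `N#Cc1ccc(S(=O)(=O)Nc2ccc(Cl)c3c(Cl)c[nH]c23)cc1`, gives 0.59 ug/mL. Compound 2, `Nc1ccc(S(=O)(=O)Nc2ccc(Cl)c3c(Cl)c[nH]c23)cc1`, gives 0.49 ug/mL. Among the measured compounds shown here, the only measured step, a 1.2-fold lower number from compound 1 to compound 2 (0.08 log units; within the scatter), places amino in place of cyano on an aromatic carbon, so compound 2 cannot be separated from compound 1 on these numbers.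

Compound 3, `Nc1ccc(S(=O)(=O)Nc2ccc(-c3ccccc3)c3c(Cl)c[nH]c23)cc1`, keeps the amino group of compound 2 but carries phenyl in place of chloro on an aromatic carbon. For the measured compounds named here, this change differs in kind from the one measured step. Going by the values given here, no measured compound shows what happens when the chloro group leaves, and a 1.2-fold lower number from compound 1 to compound 2 (0.08 log units; within the scatter) concerns a different group, so it gives only weak guidance here. With no evidence for a large shift in this assay, no step beyond the scatter is predicted, although the uncertainty is wide in both directions. The estimated change is a 1.4-fold higher number from compound 2 to compound 3 (0.15 log units; within the scatter), a slight expected lean toward a higher number. The expected value for compound 3 is 0.7 ug/mL, with an estimated range of 0.2 ug/mL to 2.5 ug/mL.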

Compound 3, half-maximal inhibitory concentration: 19 ug/mL
Compound 3: the middle estimate sits 27-fold (1.43 log units) below what was measured; measured number outside the range, above it.
By their numbers in this assay, from the lowest: compounds 2 and 1 (each within the scatter of the next); then compound 3.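

In this assay, the exchange of chloro for phenyl gives a 39-fold higher number from compound 2 to compound 3 (1.59 log units; beyond the scatter), the first change among these compounds to lie beyond the scatter. The earlier swap of cyano for amino, made in a different place, gave only a 1.2-fold lower number from compound 1 to compound 2 (0.08 log units; within the scatter), so the series had not yet shown any sensitivity to structure; this pair shows that the aromatic carbon para to a large group does not treat chloro and phenyl alike, with phenyl giving the much higher number. Nothing available bears on why the number rises so far at this position.

The compounds shown leave open whether methyl, fluoro or a plain hydrogen at this carbon would stay close to compound 2 or move towards compound 3, and whether a pyridyl or benzyl group would behave as phenyl does. Phenyl also appears here only alongside the amino group, so it remains open whether the same step would hold with the nitrile of compound 1 or with a carboxylic acid on the other ring.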